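A few compounds are considered here, and "the series" means these few. Any claim that something is new, unique, unknown or untested is made for them only; others in the source may bear on it.

Measured compounds: compound 1 `CCCCOC(=O)NS(=O)(=O)c1ccc(CCC)cc1-c1ccc(Cn2c(C3CCCCC3)nc3ccccc32)cc1`, which in an assay on membranes from HEK293 cells for displacement of a labelled ligand from Type-2 angiotensin II receptor (Homo sapiens), read by radioligand binding (on this read-out higher numbers stand for weaker inhibition and lower numbers for stronger inhibition), gives 130 nM; compound 2 `CCCCOC(=O)NS(=O)(=O)c1ccc(CCC)cc1-c1ccc(Cn2c(Cc3ccccc3)nc3ccccc32)cc1`, which in this assay gives 15 nM.

Among the compounds with values here, compound 1 holds the higher of the two numbers in this assay; its only measured neighbour is compound 2, an 8.7-fold lower number from compound 1 to compound 2 (0.94 log units; beyond the scatter). Compound 3 `CCCCOC(=O)NS(=O)(=O)c1ccc(CCC)cc1-c1ccc(Cn2c(C)nc3ccccc32)cc1` differs from compound 1 by methyl in place of cyclohexyl on an aromatic carbon. Within the data shown here, no measured step removes the ring group outright; the one known exchange at that carbon replaces it with another ring-bearing group, so it bears on this change only loosely. For compound 3 a step of a 1.5-fold higher number from compound 1 to compound 3 (0.19 log units; within the scatter) is expected, close to the scatter and of uncertain direction. Compound 3 is estimated at 200 nM, within 50 nM to 800 nM.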

Compound 3, inhibition constant: 9.4 nM
Compound 3: the middle estimate sits 21-fold (1.33 log units) above what was measured; the whole stated range lies above it.
By their numbers in this assay, from the lowest: compounds 3 and 2 (each within the scatter of the next); then compound 1.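

Within the data shown here, on the aromatic carbon between two ring nitrogen atoms, the large ring is not required in this assay: methyl in place of cyclohexyl gives a 14-fold lower number from compound 1 to compound 3 (1.14 log units; beyond the scatter), the largest step so far. Replacing phenyl with hydrogen on the chain gives a 1.6-fold lower number from compound 2 to compound 3 (0.20 log units; within the scatter), so the phenyl of the benzyl group makes no readable difference, and cyclohexyl alone stands apart from the other two groups. No evidence accounts for the gain seen with methyl. Going by these compounds, whether hydrogen, a longer chain such as butyl, or an amine on this carbon would match methyl remains open.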